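Changing the Ring Attached to the Shared Core

A few compounds are considered here, and "the series" means these few. Any claim that something is new, unique, unknown or untested is made for them only; others in the source may bear on it.

Measured so far in an assay on CHO cells for displacement of a labelled ligand from adenosine receptor A3 (Homo sapiens), read by scintillation counting, tested at 10 uM; a lower number here means less inhibition, a higher number more inhibition at the concentration tested (going by the name of the read-out):
- Compound 1 `CC(C)(C)Cc1csc(N)c1C(=O)c1ccc(Cl)cc1` gives 5%
- Compound 2 `COc1ccccc1-c1sc(N)c(C(=O)c2ccc(Cl)cc2)c1CC(C)(C)C` gives 1%
- Compound 3 `CC(C)c1ccc(-c2sc(N)c(C(=O)c3ccc(Cl)cc3)c2CC(C)(C)C)cc1` gives 1%

All three numbers are small, and every step between them stays within the scatter: a number 4 percentage points lower from compound 1 to compound 2 (within the scatter), a number 4 percentage points lower from compound 1 to compound 3 (within the scatter) and no change at the digits printed from compound 2 to compound 3 (within the scatter). Compound 3 therefore sits level with compound 2, the two sharing the lowest number of the three, with compound 1 the furthest away and still within scatter.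

Compound 4 `CC(C)(C)Cc1c(-c2cccs2)sc(N)c1C(=O)c1ccc(Cl)cc1` is the next compound; it has not yet been measured in this assay. It differs from compound 3 in one place: thiophen-2-yl in place of 4-isopropylphenyl on an aromatic carbon. Going by the values given here, the steps that bear on this are the two earlier swaps at the same aromatic carbon, from compound 1 to compound 2 and from compound 1 to compound 3, which in this assay gave a number 4 percentage points lower from compound 1 to compound 2 (within the scatter) and a number 4 percentage points lower from compound 1 to compound 3 (within the scatter), and the swap from compound 2 to compound 3 with no change at the digits printed from compound 2 to compound 3 (within the scatter). None moved beyond the scatter, so no step beyond the scatter is expected here either: the expected step is a number 1 percentage points higher from compound 3 to compound 4 (within the scatter). Compound 4 is thus estimated at 2% in this assay, expected to fall between -6% and 12%.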

Compound 4, a percentage reported as inhibition, at one concentration (the size of the read-out at that concentration, not a potency): 1%
Estimate against measurement, compound 4: 1 percentage points above; the measured number falls inside the stated range.
By their numbers in this assay, from the lowest: compounds 2, 3, 4 and 1 (each within the scatter of the next).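

Placing thiophen-2-yl on this aromatic carbon gives no change at the digits printed from compound 3 to compound 4 (within the scatter) and no change at the digits printed from compound 2 to compound 4 (within the scatter) and a number 4 percentage points lower from compound 1 to compound 4 (within the scatter) in this assay at the concentration tested. The earlier compounds shown here carried only hydrogen or a six-membered aromatic ring of carbon here, whereas compound 4 shows that a five-membered aromatic ring with a ring sulfur and a hydrogen-bond acceptor also stays within the scatter of all three. Nothing measured here explains why these numbers stay so close.

From the compounds shown here alone, what a carboxylic acid, an aliphatic amine or a longer carbon chain would do on this carbon stays open. It also stays open whether any group at this position can move the number beyond the scatter, since every step among these four compounds lies within it.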